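Three Methoxy Groups Removed One at a Time

The source may hold more compounds than are shown below. What is called first, only, known or untested is meant among the compounds shown, and "the series" means these compounds.

Three chalcone-type pyrazoles have been tested in a functional assay on A498 cells (Homo sapiens) for inhibition, read by sulforhodamine B assay, with a stated time of 48 h; a lower number here means that less compound is tolerated, a higher number that more compound is tolerated. Compound 1 `COc1ccc(-c2cc(/C=C/C(=O)c3ccc(N)cc3)[nH]n2)cc1` gives 15400 nM in this assay. Compound 2 `COc1ccc(-c2cc(/C=C/C(=O)c3ccc(N)cc3)[nH]n2)cc1OC` gives 26200 nM in this assay. Compound 3 `COc1cc(C(=O)/C=C/c2cc(-c3cc(OC)c(OC)c(OC)c3)n[nH]2)cc(OC)c1OC` gives 8020 nM in this assay. The difference between the cores of compound 3 and compound 2 is not broken down here.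

From compound 2 to compound 1 the change is hydrogen in place of methoxy on an aromatic carbon, and it brought a 1.7-fold lower number from compound 2 to compound 1 (0.23 log units; within the scatter).

Compound 4 `COc1ccc(-c2cc(/C=C/C(=O)c3cc(OC)c(OC)c(OC)c3)[nH]n2)cc1OC` has not yet been measured. From compound 3 it differs by hydrogen in place of methoxy on an aromatic carbon. This is the same kind of change as that from compound 2 to compound 1, though the surroundings are not identical: in compound 3 the carbon is also meta to a methoxy group, which is not part of the place in compound 2.

For the measured compounds named here, the expectation for compound 4 is a step of about a 1.5-fold lower number from compound 3 to compound 4 (0.16 log units; within the scatter), resting on the within-scatter step a 1.7-fold lower number from compound 2 to compound 1 (0.23 log units; within the scatter) seen for the only comparable pair. Compound 4 is therefore estimated at 5500 nM in this assay, expected to fall between 2500 nM and 12000 nM.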

Compound 4, concentration lethal to 50% of the cells: 22300 nM
Compound 4: the middle estimate sits 4.1-fold (0.61 log units) below what was measured; the whole stated range lies below it.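

In this assay the exchange of a methoxy group for hydrogen brought a 2.8-fold higher number from compound 3 to compound 4 (0.44 log units; beyond the scatter), so removing this group from compound 3 did not give the small step that the earlier pair had suggested. Set beside that earlier pair, the same change did not carry over from one core to the other: the same change on two cores in this assay, a 1.7-fold lower number (0.23 log units; within the scatter) from compound 2 to compound 1 and a 2.8-fold higher number (0.44 log units; beyond the scatter) from compound 3 to compound 4, 4.7-fold (0.67 log units) apart, beyond the scatter of two such steps

For the compounds shown here, this shows that, in this series, the step seen on one core cannot simply be transferred to the other, but with only two pairs it does not show what sets them apart, since the cores differ and the place of the change also has different surroundings.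

The compounds shown leave open whether a fluorine atom, a hydroxyl group or an ethoxy group in place of this methoxy group would also give steps that differ between the two cores. They also leave open what the same exchange would do on a third core, so no general rule for this change can yet be stated.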